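This account rests on a few compounds, and the source may have more. Where it says the series, first, only, none or still open, it means among the compounds named here.

Of the two numbers recorded so far, compound 1 `O=S(=O)(c1cccc2nonc12)N1CCOc2c(N3CCNCC3)cc(Cl)cc21` stands lowest: in an assay on HEK293 cells for displacement of a labelled ligand from 5-hydroxytryptamine receptor 6 (Homo sapiens) (on this read-out lower numbers stand for stronger inhibition and higher numbers for weaker inhibition), compound 1 gives 0.501 nM. Going by the values given here, its only companion is compound 2 `Cc1cc(N2CCNCC2)c2c(c1)N(S(=O)(=O)c1ccccc1)CCO2`, which in this assay gives 2.51 nM; the gap between the two lies beyond the usual scatter of repeated measurements, but since compound 2 differs from compound 1 in more than one place, that gap cannot be tied to any single change. Compound 3 `O=S(=O)(c1ccccc1F)N1CCOc2c(N3CCNCC3)cc(Cl)cc21` has not been measured yet. It is derived from compound 1 by one replacement: a group of 7 heavy atoms (6 carbon, 1 fluorine; one six-membered aromatic ring of carbon only) in place of a group of 9 heavy atoms (6 carbon, 2 nitrogen, 1 oxygen; one five-membered aromatic ring with 3 hetero atoms, one six-membered aromatic ring of carbon only), on a sulfonyl sulfur. Among the compounds with values here, no pair of measured compounds shows exactly this exchange, so the size of its effect is uncertain. Given that compound 1 already holds the strongest number of the pair, the replacement in compound 3 is expected to move the result modestly upward, toward weaker inhibition, by a step that is estimated as a 3.0-fold higher number from compound 1 to compound 3 (0.48 log units; beyond the scatter), beyond the scatter but not far beyond it. On that basis compound 3 is estimated to give 1.5 nM, with a likely range from 0.5 nM to 5 nM.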

Compound 3, inhibition constant: 0.398 nM
Estimate against measurement, compound 3: 3.8-fold (0.58 log units) above; measured number below the stated range.
By their numbers in this assay, from the lowest: compounds 3 and 1 (each within the scatter of the next); then compound 2.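

Going by these compounds alone, this is the first pair that differs in only one place, so a change on the sulfonyl sulfur can now be read on its own: in this assay, replacing the two-ring group of compound 1 with 2-fluorophenyl gives a 1.3-fold lower number from compound 1 to compound 3 (0.10 log units; within the scatter). The two groups therefore cannot be told apart on this read-out, even though they differ considerably in what is counted for them: the group in compound 1 has a five-membered aromatic ring with 3 hetero atoms and 3 hydrogen-bond acceptors, whereas 2-fluorophenyl has a single six-membered carbon ring and 0 hydrogen-bond acceptors. So, with the rest of compound 1 unchanged, neither that five-membered ring nor those acceptors are needed for a number in this range, though nothing measured here explains why the two groups match.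

From the compounds shown here alone, whether the fluorine matters remains open, as a plain phenyl group on the same core would be needed to test it. It is also unknown how far this tolerance extends, for example to a pyridine ring, a small methyl group, or a phenyl ring carrying a carboxylic acid or an amine.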